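The compounds below may be only part of what the source reports. "The series", "measured", "known", "first", "only" and "open" are said of these compounds alone.

Compound 1 `CC#CCn1c(N2CCC[C@@H](N)C2)nc2c1c(=O)n(Cc1c(Br)cccc1C(=O)O)c(=O)n2C`, compound 2 `CC#CCn1c(N2CCC[C@@H](N)C2)nc2c1c(=O)n(Cc1cc(C#N)ccc1C(=O)O)c(=O)n2C` and compound 3 `CC#CCn1c(N2CCC[C@@H](N)C2)nc2c1c(=O)n(Cc1cc(Cl)ccc1C(=O)O)c(=O)n2C`.

In an ADME assay on isolated protein for inhibition of Dipeptidyl peptidase 9 (Homo sapiens), with stated times of 15 min, 60 s and 20 min (on this read-out higher numbers stand for weaker inhibition and lower numbers for stronger inhibition), compound 1 gives only a limit, > 100000 nM. In this assay compound 2 likewise reaches only a limit, > 100000 nM. Compound 3 also gives a limit, > 100000 nM. Compound 2 thus stands at the limit together with the other two values, as the limit of > 100000 nM in this assay, at which 3 of the 3 values shown sit, shows. Compound 4 `CC#CCn1c(N2CCC[C@@H](N)C2)nc2c1c(=O)n(Cc1c(OC)cccc1C(=O)O)c(=O)n2C` is not yet measured; it differs from compound 2 in one place: 2-carboxy-6-methoxyphenyl in place of 2-carboxy-5-cyanophenyl on a saturated chain carbon bound to an aromatic nitrogen. Within the data shown here, the steps that bear on this change, a step that the two limits leave unreadable from compound 1 to compound 2 and a step that the two limits leave unreadable from compound 2 to compound 3, are unreadable in size, as is a step that the two limits leave unreadable from compound 1 to compound 3. With no readable step anywhere in the series, compound 4 is expected to sit at the limit as well, so a step that the limit leaves unreadable from compound 2 to compound 4 is estimated. Compound 4 is expected to give 150000 nM, between 50000 nM and 500000 nM.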

Compound 4, half-maximal inhibitory concentration: > 100000 nM
Compound 4: no number, only a limit (the forecaster's own chance of this, stated with the estimate: 85%); the middle value lies beyond the limit too.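

Compound 4, like compounds 1, 2 and 3, gives only a limit in this assay, so none of the steps among them can be read: the limit of > 100000 nM in this assay, at which 4 of the 4 values shown sit.

The compounds shown leave open how far beyond that limit each one lies, and whether any of them differs from the others in inhibition.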